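Series notes: nitro in place of fluoro, compound 4

The source may hold more compounds than are shown below. What is called first, only, known or untested is meant among the compounds shown, and "the series" means these compounds.

Three measured compounds share one core: compound 1 `Fc1ccc(/C=N/NC(=S)Nc2nc3ccc(Cl)cc3s2)cc1`, compound 2 `O=C(Cn1ccc2ccccc21)Nc1nc2ccc(Cl)cc2s1` and compound 3 `O=C(CN(c1ccccc1)c1ccccc1)Nc1nc2ccc(Cl)cc2s1`. In a functional assay on the whole organism with Mus musculus as the target, in the maximal electroshock model, with a stated time of 0.5 h (a higher number here means that more compound is needed for the effect, a lower number that less compound is needed), compound 1 gives 30 mg/kg, the lowest of the three numbers. Compound 2 gives 100 mg/kg in this assay, a higher number that lies beyond the usual scatter. Compound 3 gives 300 mg/kg in this assay, higher still and again beyond the scatter. Compound 1 is thus the member of the three that needs the least material for the effect.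

Compound 4 `O=[N+]([O-])c1ccc(/C=N/NC(=S)Nc2nc3ccc(Cl)cc3s2)cc1` is not yet measured. It differs from compound 1 in one place: nitro in place of fluoro on an aromatic carbon. Going by the values given here, no pair of measured compounds differs in a single place, so nothing in this set calibrates the size of such an exchange. Compounds 2 and 3 differ from compound 1 elsewhere and carry higher numbers, which says nothing about this exchange. The expectation in this assay is therefore no step beyond the scatter in either direction, written as no change at the digits printed from compound 1 to compound 4 (within the scatter). Compound 4 is estimated at 30 mg/kg, with a range from 10 mg/kg to 100 mg/kg.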

Compound 4, minimum effective dose: 100 mg/kg
Compound 4: the middle estimate sits 3.3-fold (0.52 log units) below what was measured; low and high end bracket the measured number.
By their numbers in this assay, from the lowest: compound 1; then compounds 2 and 4 (each within the scatter of the next); then compound 3.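

Compound 4 gives the series its first step in one place: in this assay, nitro in place of fluoro on an aromatic carbon, para to a large group, brings a 3.3-fold higher number from compound 1 to compound 4 (0.52 log units; beyond the scatter). This position is therefore not indifferent to the group it carries, although the step is modest and compound 4 still gives a measured minimum effective dose. No measurement shown here bears on why the step occurs.

As far as these compounds go, a single exchange at a single place sets no trend, so it remains open whether fluoro is a favoured group here or nitro merely a disfavoured one. An amine, a methoxy group or a carboxylic acid on the same carbon would begin to separate these readings in this assay.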